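Cytotoxicity of a hydrazone series: estimating a dihydroxyphenyl analogue

The source may report more compounds than this note shows. Statements on the series, on what has been measured and on what is new or still open speak of the compounds shown alone.

Compound 1, `COc1ccccc1-c1nnc(-c2ccc(C(=O)N/N=C/c3ccc(F)cc3)cc2)o1`, gives 427000 nM in an ADME assay on THP-1 cells (Homo sapiens) for cytotoxicity; a lower number here means a stronger inhibitor, a higher number a weaker inhibitor.
Compound 2, `COc1ccccc1-c1nnc(-c2ccc(C(=O)N/N=C/c3ccc([N+](=O)[O-])cc3)cc2)o1`, gives 203000 nM in this assay.
Compound 3, `COc1ccccc1-c1nnc(-c2ccc(C(=O)N/N=C/c3cccc(O)c3)cc2)o1`, gives 398000 nM in this assay.

Going by the values given here, compound 2 stands at the lowest of the three numbers, but only the step to compound 1 lies beyond the scatter: a 2.1-fold lower number from compound 1 to compound 2 (0.32 log units; beyond the scatter). Its gap to compound 3 does not: a 2.0-fold higher number from compound 2 to compound 3 (0.29 log units; within the scatter). Compound 4, `COc1ccccc1-c1nnc(-c2ccc(C(=O)N/N=C/c3ccc(O)c(O)c3)cc2)o1`, has not yet been measured. It differs from compound 2 in one place: 3,4-dihydroxyphenyl in place of 4-nitrophenyl on a carbon with a double bond to nitrogen.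

Among the compounds with values here, the step that bears most directly on this change is the one from compound 2 to compound 3, where a 3-hydroxyphenyl also replaces the 4-nitrophenyl, and it stayed within the scatter. The step from compound 1 to compound 2 shows that removing or adding the nitro moves the number only modestly. Compound 4 is therefore expected to land close to compound 3, with no step beyond the scatter from compound 2: a 1.7-fold higher number from compound 2 to compound 4 (0.24 log units; within the scatter). The estimate for compound 4 is 350000 nM, with a range from 180000 nM to 700000 nM.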

Compound 4, half-maximal inhibitory concentration: 100000 nM
Compound 4: middle estimate off by 3.5-fold (0.54 log units), on the high side; the whole stated range lies above it.
By their numbers in this assay, from the lowest: compound 4; then compounds 2, 3 and 1 (each within the scatter of the next, the first and the last beyond it).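

In this assay, the second hydroxy is the change that counts: hydroxy in place of hydrogen on an aromatic carbon gives a 4.0-fold lower number from compound 3 to compound 4 (0.60 log units; beyond the scatter). The 3-hydroxyphenyl of compound 3 stayed within the scatter of the 4-nitrophenyl and the 4-fluorophenyl rings, whereas the 3,4-dihydroxyphenyl separates from both, with a 2.0-fold lower number from compound 2 to compound 4 (0.31 log units; beyond the scatter) and a 4.3-fold lower number from compound 1 to compound 4 (0.63 log units; beyond the scatter), which makes compound 4 the lowest of the four. The data offer nothing that explains this shift.

The compounds shown leave open whether the drop depends on the free hydroxy groups themselves, or whether methoxy groups, an amine or a carboxylic acid on the same ring would give a similar number. They also leave open whether the same step would hold on a different core.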